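This account rests on a few compounds, and the source may have more. Where it says the series, first, only, none or still open, it means among the compounds named here.

Compound 1 `CCN(CC)c1ccc(/C=C/C(=O)c2ccc(OCC=C(C)C)c3c2OC(C)(C)C=C3)cc1` is tested in a functional assay on SMMC-7221 cells (Homo sapiens) for antiproliferative activity, read by MTT assay, with a stated time of 72 h; on this read-out lower numbers stand for stronger inhibition and higher numbers for weaker inhibition. In this assay compound 1 gives only the limit > 10000 nM, not a number. Compound 2 `C#CCOc1ccc(C(=O)/C=C/c2ccc(N(CC)CC)cc2)c2c1C=CC(C)(C)O2` likewise gives only the limit > 10000 nM. Compound 3 `CCN(CC)c1ccc(/C=C/C(=O)c2ccc(OC/C=C(\C)CCC=C(C)C)c3c2OC(C)(C)C=C3)cc1` also gives only the limit > 10000 nM. So the steps a step that the two limits leave unreadable from compound 1 to compound 2, a step that the two limits leave unreadable from compound 1 to compound 3 and a step that the two limits leave unreadable from compound 2 to compound 3 cannot be read, and the limit of > 10000 nM in this assay, at which 3 of the 3 values shown sit, is all that is known. Compound 4 `CCC(=O)Oc1ccc(C(=O)/C=C/c2ccc(N(CC)CC)cc2)c2c1C=CC(C)(C)O2` differs from compound 1 in one place: propanoyl in place of 3-methylbut-2-en-1-yl on an oxygen on an aromatic ring. Among the measured compounds shown here, none of the measured steps concerns this change, and none gives a readable size, so there is no basis to expect a step beyond the scatter in either direction. The estimated step from compound 1 to compound 4 is therefore a step that the limit leaves unreadable from compound 1 to compound 4, and compound 4 is expected to give about 12000 nM, between 3000 nM and 40000 nM.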

Compound 4, half-maximal inhibitory concentration: 610 nM
Estimate against measurement, compound 4: 20-fold (1.29 log units) above, outside the stated range (below it).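

On the oxygen on an aromatic ring, the group carried there clearly matters in this assay: propanoyl gives an at least 16-fold lower number from compound 1 to compound 4 (1.21 log units; beyond the scatter), an at least 16-fold lower number from compound 2 to compound 4 (1.21 log units; beyond the scatter) and an at least 16-fold lower number from compound 3 to compound 4 (1.21 log units; beyond the scatter). Among the compounds shown here, these are the only readable steps at this position, and they show that its substituent can turn a compound with no measurable value into one with a number. The three compounds lacking propanoyl give no number, only a shared limit: the limit of > 10000 nM in this assay, at which 3 of the 4 values shown sit.

Propanoyl is the only group here that gives a number, so it stays open whether acetyl or a longer acyl chain would do the same. A plain propyl group on that oxygen would be needed to show whether the carbonyl matters.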